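The source may hold more compounds than are shown below. What is called first, only, known or untested is meant among the compounds shown, and "the series" means these compounds.

Of the compounds shown here, three built on one shared core have been measured in an assay on CHO cells for displacement of a labelled ligand from adenosine receptor A1 (Homo sapiens), read by scintillation counting, with a stated time of 120 min, tested at 10 uM; on this read-out lower numbers stand for less inhibition and higher numbers for more inhibition at the one concentration tested (going by the name of the read-out). Compound 1, `Nc1scc(CN2CCN(c3cc(Cl)cc(Cl)c3)CC2)c1C(=O)c1ccc(Cl)cc1`, gives 1% in this assay. Compound 2, `Nc1scc(CN2CCN(c3ccncc3)CC2)c1C(=O)c1ccc(Cl)cc1`, gives 1%. Compound 3, `Nc1scc(CN2CCN(c3cccc(F)c3)CC2)c1C(=O)c1ccc(Cl)cc1`, gives 1%. Each of these three differs from the others only in the aromatic group carried on an amine nitrogen in a ring, and the read-out is the same at the digits shown for all of them: no change at the digits printed from compound 1 to compound 2 (within the scatter), no change at the digits printed from compound 1 to compound 3 (within the scatter) and no change at the digits printed from compound 2 to compound 3 (within the scatter). Compound 3 therefore stands level with compounds 1 and 2, with none of the three set apart from the others.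

Compound 4, `Nc1scc(CN2CCN(c3ccccc3Cl)CC2)c1C(=O)c1ccc(Cl)cc1`, has not yet been measured. It differs from compound 3 in one place: 2-chlorophenyl in place of 3-fluorophenyl on an amine nitrogen in a ring. All three measured steps bear on this change, since each of them also exchanges one aromatic group for another at the same amine nitrogen in a ring, and each of them stayed within the scatter. Nothing in the measured steps points toward a shift in either direction, so the expected step is none beyond the scatter: a number 1 percentage points higher from compound 3 to compound 4 (within the scatter). Compound 4 is accordingly estimated at 2% in this assay, within a range from -8% to 12%.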

Compound 4, a percentage reported as inhibition, at one concentration (the size of the read-out at that concentration, not a potency): 2%
Compound 4: middle estimate and measured number agree at the digits printed; low and high end bracket the measured number.
By their numbers in this assay, from the lowest: compounds 1, 2, 3 and 4 (each within the scatter of the next).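

In this assay, putting 2-chlorophenyl on the amine nitrogen in a ring leaves compound 4 within the scatter of all three earlier compounds, with a number 1 percentage points higher from compound 3 to compound 4 (within the scatter), a number 1 percentage points higher from compound 2 to compound 4 (within the scatter) and a number 1 percentage points higher from compound 1 to compound 4 (within the scatter). The earlier compounds shown here covered 3,5-dichlorophenyl, pyridin-4-yl and 3-fluorophenyl at this place, so 2-chlorophenyl adds a fourth aromatic group, and across these four compounds the choice of group produces no step beyond the scatter, including the exchange of a fluorine-bearing ring for a chlorine-bearing ring of the same heavy-atom count. Nothing measured here explains why these four groups give such closely matching numbers.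

The compounds shown leave open whether any group on this nitrogen can lift the read-out clear of the scatter, for example a benzyl group, a plain alkyl chain, or a phenyl ring carrying a carboxylic acid or an amine. They also leave open whether a change elsewhere on the shared core, rather than at this nitrogen, would move the number in this assay at all.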